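Ethyl for ethoxy on the pyrimidine of compound 3

The source may hold more compounds than are shown below. What is called first, only, known or untested is meant among the compounds shown, and "the series" means these compounds.

Compound 1: `CCc1cnc(N2CCC([C@H]3C[C@H]3COCc3ccc(S(C)(=O)=O)cn3)CC2)nc1` gives 1.5 nM in a functional assay on CHO cells for agonist activity at Glucose-dependent insulinotropic receptor (Homo sapiens), read by cAMP accumulation; a higher number here means that more compound is needed for the effect, a lower number that less compound is needed.
Compound 2: `CC(C)c1noc(N2CCC([C@H]3C[C@H]3COCc3ccc(S(C)(=O)=O)cc3F)CC2)n1` gives 4.2 nM in this assay.
Compound 3: `CCOc1cnc(N2CCC([C@H]3C[C@H]3COCc3ccc(S(C)(=O)=O)c(F)c3)CC2)nc1` gives 1.7 nM in this assay.

Among these three, compound 3 stands second highest. Its nearest neighbour is compound 1, whose value lies within the scatter of that of compound 3, so no order between the two can be stated. Its furthest neighbour is compound 2, whose value lies beyond the scatter, higher than that of compound 3.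

Compound 4 is `CCc1cnc(N2CCC([C@H]3C[C@H]3COCc3ccc(S(C)(=O)=O)c(F)c3)CC2)nc1`. It differs from compound 3 in one place: ethyl in place of ethoxy on an aromatic carbon. Among the compounds with values here, no measured pair shows this change on its own. What the data show is that compound 1, which carries the ethyl on the same ring but a different aromatic unit at the far end, gives 1.5 nM, a value within the scatter of compound 3. This gives no reason to expect that the exchange of ethoxy for ethyl moves the number beyond the scatter in either direction.

On this basis compound 4 is expected to come out at about 1.8 nM, with a range from 0.8 nM to 4 nM. The step this estimate means, a 1.1-fold higher number from compound 3 to compound 4 (0.02 log units; within the scatter), is expected to lie within the scatter.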

Compound 4, half-maximal effective concentration in the Glucose-dependent insulinotropic receptor assay: 2.5 nM
Compound 4: middle estimate off by 1.4-fold (0.14 log units), on the low side; the range from low to high includes it.
By their numbers in the Glucose-dependent insulinotropic receptor assay, from the lowest: compounds 1, 3, 4 and 2 (each within the scatter of the next, the first and the last beyond it).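

With the far end of the molecule held constant, the exchange of 5-ethoxypyrimidin-2-yl for 5-ethylpyrimidin-2-yl can now be read on its own, which in the Glucose-dependent insulinotropic receptor assay compound 1, at 1.5 nM, could not offer, since it also carries a different aromatic unit. In the Glucose-dependent insulinotropic receptor assay the exchange gives a 1.5-fold higher number from compound 3 to compound 4 (0.17 log units; within the scatter), so at this position, para to a large group, removing the oxygen and its one hydrogen-bond acceptor leaves the number within the usual scatter, and in a physicochemical assay for lipophilicity, read by HPLC, at pH 7 (a lower number here means a more polar compound, a higher number a more lipophilic compound), where compound 3 gives 4.2 and compound 4 gives 4.3, the same exchange gives a number 0.10 log units higher from compound 3 to compound 4 (within the scatter), so neither read-out separates the two groups. Nothing among the data shown offers an explanation for either result.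

Ethoxy and ethyl are close in size, so the pair says little about how far this position can be varied; a carboxylic acid, a primary amine or a longer chain such as hexyl on the same aromatic carbon would test that much more severely. On these data alone, it also remains open whether the exchange reads the same with other far-end units, such as that of compound 1, because this single pair speaks only for the far end it shares.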